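This account rests on a few compounds, and the source may have more. Where it says the series, first, only, none or still open, it means among the compounds named here.

Measured so far in a functional assay on MDA-MB-436 cells (Homo sapiens) for antiproliferative activity, read by MTT assay, with a stated time of 24 h; on this read-out lower numbers stand for stronger inhibition and higher numbers for weaker inhibition:
Compound 1 `O=C(O)CC(NS(=O)(=O)c1ccccc1)c1ccccc1`: > 100000 nM (a limit)
Compound 2 `N#Cc1ccc(S(=O)(=O)NC(CC(=O)O)c2ccccc2)cc1`: 59300 nM
Compound 3 `O=C(O)CC(NS(=O)(=O)c1ccccc1)c1ccccc1F`: > 100000 nM (a limit)

Compound 3 stands at a limit of this assay, > 100000 nM, and so has no actual number. Among the measured compounds shown here, the values so far are dominated by the limit of > 100000 nM in this assay, at which 2 of the 3 values shown sit.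

Compound 4 `O=C(O)CC(NS(=O)(=O)c1ccc(C(F)(F)F)cc1)c1ccccc1F` differs from it by trifluoromethyl in place of hydrogen on an aromatic carbon, para to a large group: trifluoromethyl in place of hydrogen on an aromatic carbon. The nearest measured step is cyano in place of hydrogen on an aromatic carbon, an at least 1.6-fold lower number from compound 1 to compound 2 (0.22 log units; that floor lies within the scatter). This step gives only a floor, and that floor lies within the scatter. For the measured compounds named here, it is still the step that leads to the only real number, with compound 2 at 59300 nM. The fluoro step, a step that the two limits leave unreadable from compound 1 to compound 3, cannot be read.

A modest move towards a lower number is therefore expected, though a second reading at the limit would be no surprise. The estimated step is an at least 1.4-fold lower number from compound 3 to compound 4 (0.15 log units; that floor lies within the scatter). For compound 4 the estimated value is 70000 nM, with an expected range of 30000 nM to 100000 nM.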

Compound 4, half-maximal inhibitory concentration: 55600 nM
For compound 4 the middle estimate is 1.3-fold (0.10 log units) above the measured one; the measured number falls inside the stated range.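

Trifluoromethyl at this place, on an aromatic carbon para to a large group, brings a real reading in this assay to a compound whose parent had none: compound 3 stands only at a limit, > 100000 nM. The change amounts to an at least 1.7-fold lower number from compound 3 to compound 4 (0.25 log units; that floor lies within the scatter). It is the second replacement of aromatic hydrogen, after the cyano of compound 2, to give a real number, and it does so on the fluoro-bearing core, although neither floor clears the scatter.

On these data alone, the true size of either step stays open, and the fluoro step from compound 1 to compound 3 cannot be read: the limit of > 100000 nM in this assay, at which 2 of the 4 values shown sit. Whether an amine, a methoxy group or a longer chain at this place would lower the number further is also left open.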